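The source may hold more compounds than are shown below. What is called first, only, known or untested is meant among the compounds shown, and "the series" means these compounds.

Of the compounds shown here, two from this study have been measured in an ADME assay on A549 cells (Homo sapiens) for cytotoxicity, read by resazurin assay, with a stated time of 48 h; on this read-out higher numbers stand for lower toxicity in this test and lower numbers for higher toxicity in this test. Compound 1 `CC1CN(C(=O)OC(C)(C)C)CCN1C(=O)Nc1ccc([N+](=O)[O-])cc1` gives 143000 nM in this test. Compound 2 `CC(C)(C)OC(=O)N1CCN(C(=O)Nc2ccc(C#N)cc2)C(c2ccccc2)C1` gives 91300 nM, the lowest of the two numbers, yet compound 1 sits within the usual scatter of it, so the two cannot be told apart by this read-out. For the measured compounds named here, no pair of measured compounds differing in a single place is available, so nothing measured speaks directly to what one small change does to the toxicity here. Compound 3 `Cc1ccc(NC(=O)N2CCN(C(=O)OC(C)(C)C)CC2c2ccccc2)cc1` differs from compound 2 in one place: methyl in place of cyano on an aromatic carbon. With no guidance from the two measured compounds, the step of a 1.1-fold higher number from compound 2 to compound 3 (0.04 log units; within the scatter) is expected to be small, not beyond the scatter, in either direction. Compound 3 is therefore estimated at 100000 nM, with a range from 40000 nM to 250000 nM.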

Compound 3, half-maximal cytotoxic concentration: 165000 nM
The estimate for compound 3 lay 1.7-fold (0.22 log units) below the measured number; measured number inside the range.
By their numbers in this assay, from the lowest: compounds 2, 1 and 3 (each within the scatter of the next).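

Exchanging cyano for methyl on the aromatic carbon para to a large group gives a 1.8-fold higher number from compound 2 to compound 3 (0.26 log units; within the scatter) in this assay. For the compounds shown here, this is the first single-place comparison available, and it shows that going from 4-cyanophenyl to 4-methylphenyl does not separate the two compounds in this test. At this position, then, a nitrile with its triple bond and hydrogen-bond acceptor and a methyl with no acceptor cannot be told apart by this read-out, and no other measurement here offers an explanation for the size of this step.

As far as these compounds go, whether an amine, a carboxylic acid or a longer chain at the same position would also stay within the scatter remains open. Going by these compounds alone, compound 1 differs from compound 2 and compound 3 in more than one place, so no step involving it can be read.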